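Swapping a methyl for a fluoro on the aryl sulfide arm

The source may report more compounds than this note shows. Statements on the series, on what has been measured and on what is new or still open speak of the compounds shown alone.

Three compounds share a core in which an aminophenyl amide is joined to a benzyl sulfide. Compound 1 `Nc1ccccc1NC(=O)c1ccc(CSc2nccc(C(F)(F)F)n2)cc1` carries a trifluoromethyl-bearing pyrimidine on the sulfur. In a functional assay on SMMC-7721 cells (Homo sapiens) for antiproliferative activity, read by CCK-8 assay, with a stated time of 72 h (on this read-out higher numbers stand for weaker inhibition and lower numbers for stronger inhibition), compound 1 gives 1890 nM. Compound 2 `Cc1ccc(SCc2ccc(C(=O)Nc3ccccc3N)cc2)cc1` instead carries a 4-methylphenyl on the sulfur, and in this assay compound 2 gives 3740 nM, the higher of the two numbers available, though its gap to compound 1 lies within the usual scatter of this measurement, so the two cannot be ranked against each other. Compound 3 `Nc1ccccc1NC(=O)/C=C/c1ccc(CSc2cccc3ccccc23)cc1` places an acrylamide linker and a naphthyl sulfide on the same core; in this assay compound 3 gives "not determined" (no result reported), so no numerical result is available for it.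

Compound 4 `Nc1ccccc1NC(=O)c1ccc(CSc2ccc(F)cc2)cc1` differs from compound 2 by a single atom: fluoro in place of methyl on an aromatic carbon. Going by the values given here, no measured pair in this set isolates that change, so nothing here indicates a direction. The step is expected to stay within the scatter, a 1.2-fold lower number from compound 2 to compound 4 (0.10 log units; within the scatter), and compound 4 is estimated at 3000 nM, in a range from 1200 nM to 7500 nM.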

Compound 4, half-maximal inhibitory concentration: 5770 nM
Compound 4: middle estimate off by 1.9-fold (0.28 log units), on the low side, within the range that was stated.
By their numbers in this assay, from the lowest: compounds 1, 2 and 4 (each within the scatter of the next, the first and the last beyond it).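

In this assay, fluoro in place of methyl on this aromatic carbon gives a 1.5-fold higher number from compound 2 to compound 4 (0.19 log units; within the scatter), so the change leaves the two compounds within the scatter of each other. Going by these compounds alone, this is the only pair here that differs in one place, and it shows that at this position, para to a large group, the measurement cannot tell methyl and fluoro apart. Nothing available explains the two numbers or bears on this change.

From the compounds shown here alone, whether an amine, a carboxylic acid or a longer chain on the same carbon would separate from methyl and fluoro remains open. So does whether the same swap would give a similar result on a different arm, such as the pyrimidine of compound 1 or the naphthyl of compound 3.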